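The source may report more compounds than this note shows. Statements on the series, on what has been measured and on what is new or still open speak of the compounds shown alone.

In an assay on HEK293 cells for inhibition of Voltage-dependent T-type calcium channel subunit alpha-1G (Homo sapiens), read by fluorescence, tested at 10 uM (on this read-out higher numbers stand for more inhibition at the one concentration tested (going by the name of the read-out) and lower numbers for less inhibition), three compounds that share one core have been measured. Compound 1 `CCCc1nc(-c2ccccc2)c(CNCCN2CCN(c3ccc(Cl)cc3)CC2)o1` gives 55.8%, compound 2 `CCCc1nc(-c2ccccc2)c(CNCCN2CCN(c3cccc(C)c3)CC2)o1` gives 43.1%, and compound 3 `CCCc1nc(-c2ccccc2)c(CNCCN2CCN(c3cccc(C)c3C)CC2)o1` gives 66.7%. Compound 3 thus stands highest of the three, beyond the scatter against both others. Compound 4 `CCCc1nc(-c2ccccc2)c(CNCCN2CCN(c3ccccc3C)CC2)o1` differs from compound 3 in one place: hydrogen in place of methyl on an aromatic carbon, on an aromatic carbon that is ortho to a methyl group. The step that bears on this is a number 23.6 percentage points higher from compound 2 to compound 3 (beyond the scatter), where a methyl took the place of a hydrogen on an aromatic carbon. Taking a methyl away from compound 3 is therefore expected to lower the number, though a number 10.9 percentage points higher from compound 1 to compound 3 (beyond the scatter) was only modest, so a moderate drop rather than a collapse is expected. Compound 4 is expected to give 50%, between 32% and 68%, an expected step of a number 16.7 percentage points lower from compound 3 to compound 4 (beyond the scatter).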

Compound 4, a percentage reported as inhibition, at one concentration (the size of the read-out at that concentration, not a potency): 51.3%
Compound 4: middle estimate off by 1.3 percentage points, on the low side, and the stated range covers the measured number.
By their numbers in this assay, from the lowest: compounds 2, 4 and 1 (each within the scatter of the next, the first and the last beyond it); then compound 3.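

In this assay, taking away either methyl of the 2,3-dimethylphenyl group now lowers the number beyond the scatter, here on going to 2-methylphenyl (a number 15.4 percentage points lower from compound 3 to compound 4 (beyond the scatter)), so the pair does more than either single methyl. A lone methyl shows no clear effect of its place (a number 8.2 percentage points higher from compound 2 to compound 4 (within the scatter)), and 2-methylphenyl cannot be told apart from 4-chlorophenyl (a number 4.5 percentage points lower from compound 1 to compound 4 (within the scatter)). Nothing at hand explains these results. Still open, from the compounds shown here alone, is whether an ethyl or a methoxy on this aromatic carbon could stand in for the methyl.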